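A few compounds are considered here, and "the series" means these few. Any claim that something is new, unique, unknown or untested is made for them only; others in the source may bear on it.

Measured so far in an assay on isolated protein for inhibition of RAC-alpha serine/threonine-protein kinase (Homo sapiens), read by fluorescence, with a stated time of 30 min, tested at 10 uM; on this read-out lower numbers stand for less inhibition and higher numbers for more inhibition at the one concentration tested (going by the name of the read-out):
- compound 1 `O=S(=O)(Nc1ccc(O)c(Sc2ncn[nH]2)c1)c1c(Cl)cccc1Cl` gives 48.4%
- compound 2 `Cc1nnc(Sc2cc(NC(=O)c3ccc([N+](=O)[O-])cc3)ccc2O)s1` gives 12.4%
- compound 3 `O=C(Nc1ccc(O)c(Sc2ncn[nH]2)c1)c1ccc([N+](=O)[O-])cc1` gives 50.7%

Compound 1 stands second highest of the three numbers. Its nearest neighbour is compound 3, whose value lies within the scatter of compound 1; the furthest is compound 2, which lies beyond the scatter, lower. Going by the values given here, the one measured step, a number 38.3 percentage points higher from compound 2 to compound 3 (beyond the scatter), concerns the ring on the thioether sulfur, with 1H-1,2,4-triazol-5-yl in place of 5-methyl-1,3,4-thiadiazol-2-yl, and says nothing about the sulfonamide side of the core.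

Compound 4 `CS(=O)(=O)Nc1ccc(O)c(Sc2ncn[nH]2)c1` differs from compound 1 by methyl in place of 2,6-dichlorophenyl on a sulfonyl sulfur. Among the compounds with values here, no measured step covers a change on the sulfonyl sulfur; the measured series leaves this position untested. The expectation therefore rests only on compound 1 itself. A moderate drop in inhibition is expected in this assay, a number 15.4 percentage points lower from compound 1 to compound 4 (beyond the scatter), with a wide range. Compound 4 is estimated at 33%, between 12% and 55%.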

Compound 4, a percentage reported as inhibition, at one concentration (the size of the read-out at that concentration, not a potency): 14.3%
The estimate for compound 4 lay 18.7 percentage points above the measured number; the measured number falls inside the stated range.
By their numbers in this assay, from the lowest: compounds 2 and 4 (each within the scatter of the next); then compounds 1 and 3 (each within the scatter of the next).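

In this assay, the group on the sulfonyl sulfur clearly affects the read-out: a number 34.1 percentage points lower from compound 1 to compound 4 (beyond the scatter), with methyl in place of 2,6-dichlorophenyl. Going by these compounds alone, the earlier step covered only the ring on the thioether sulfur, so this is the first evidence that the sulfonamide side of the core also matters, here with 1H-1,2,4-triazol-5-yl held constant. No available evidence accounts for this loss.

This single step does not separate the loss of the aromatic ring from the loss of its two chlorine atoms, and an unsubstituted phenyl or a butyl chain on the sulfonyl sulfur would help to tell these apart. Going by these compounds, it also remains open whether replacing the ring on the carbonyl of compound 3 with methyl would give a comparable result.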